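The source may hold more compounds than are shown below. What is called first, only, known or untested is meant among the compounds shown, and "the series" means these compounds.

Of the compounds shown here, three built on the same core have been measured in a toxicity assay on MCF-10A cells (Homo sapiens) for cytotoxicity, read by MTT assay, with a stated time of 48 h; on this read-out lower numbers stand for stronger inhibition and higher numbers for weaker inhibition. Compound 1 `O=C(/C=C/c1ccc2c(c1)B(O)OC2)c1ccc(-c2ccccc2)cc1` gives 20700 nM. Compound 3 `O=C(/C=C/c1ccc2c(c1)B(O)OC2)c1ccc(C(F)(F)F)cc1` gives 22300 nM. Compound 2 `O=C(/C=C/c1ccc2c(c1)B(O)OC2)c1cccnc1` gives 34400 nM. Compound 2 thus sits at the high end of the three numbers, yet its gaps to compound 3 and to compound 1 both fall inside the usual scatter, so the three cannot be told apart with confidence.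

The next compound, compound 4 `Cc1cccc(C(=O)/C=C/c2ccc3c(c2)B(O)OC3)c1`, differs from compound 2 in one place: 3-methylphenyl in place of pyridin-3-yl on a carbonyl carbon. The group attached to the carbonyl carbon is swapped while everything else stays the same.

Among the compounds with values here, only one measured step bears on this kind of change. From compound 1 to compound 3 the group on the aromatic ring of the ketone was exchanged, and the result was a 1.1-fold higher number from compound 1 to compound 3 (0.03 log units; within the scatter). That exchange did not move the read-out beyond the scatter, which suggests that the part of the molecule attached to the carbonyl tolerates changes without a clear shift in this assay. The swap from pyridin-3-yl to 3-methylphenyl is a different change, so the evidence is thin, but nothing here points to a large movement in either direction.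

The expected step is therefore a 1.4-fold lower number from compound 2 to compound 4 (0.14 log units; within the scatter), within the scatter. Compound 4 is estimated at 25000 nM, with a likely range from 12000 nM to 50000 nM.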

Compound 4, half-maximal inhibitory concentration: 15900 nM
Estimate against measurement, compound 4: 1.6-fold (0.20 log units) above; the measured number falls inside the stated range.
By their numbers in this assay, from the lowest: compounds 4, 1, 3 and 2 (each within the scatter of the next, the first and the last beyond it).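

In this assay, the group on the carbonyl carbon can move the number: there is a 2.2-fold lower number from compound 2 to compound 4 (0.34 log units; beyond the scatter), the only step among these compounds that lies beyond the scatter, although it is a modest one. The other step, a 1.1-fold higher number from compound 1 to compound 3 (0.03 log units; within the scatter), stayed within the scatter, but it exchanged a group carried on the aromatic ring and left that ring in place, whereas here the ring on the carbonyl carbon is itself replaced, with pyridin-3-yl, which has a hetero atom in its ring, giving way to 3-methylphenyl, whose ring is carbon only. No measurement shown here explains why this swap shifts the number.

This single swap removes the ring nitrogen and adds a methyl group at once, so the compounds shown cannot say which of the two changes carries the step, and a plain phenyl ring on the carbonyl carbon would be needed to separate them. As far as these compounds go, how an amine or a carboxylic acid on that ring would behave in this assay also remains open.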